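Three limits, a piperazine swap, and an expected fourth limit

A few compounds are considered here, and "the series" means these few. Any claim that something is new, unique, unknown or untested is made for them only; others in the source may bear on it.

Compound 1, `CCC(=O)Nc1ccc(S(=O)(=O)N(CC(N)=O)c2ccc(N(CC(N)=O)S(=O)(=O)c3ccc(OC)cc3)c3ccccc23)cc1`, in a functional assay on cells (Peritoneal macrophage, Mus musculus) for cytotoxicity, with a stated time of 24 h (a higher number here means that more compound is tolerated, a lower number that less compound is tolerated), gives > 50000 nM, which is a limit of the assay rather than a number.
Compound 2, `CCCCC(=O)Nc1ccc(S(=O)(=O)N(CC(N)=O)c2ccc(N(CC(N)=O)S(=O)(=O)c3ccc(OC)cc3)c3ccccc23)cc1`, in this assay gives > 100000 nM, again a limit.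
Compound 3, `COc1ccc(S(=O)(=O)N(CC(N)=O)c2ccc(N(CC(N)=O)S(=O)(=O)c3ccc(NC(=O)CCN4CCCCC4)cc3)c3ccccc23)cc1`, in this assay gives > 100000 nM, also a limit.

Compound 3 therefore stands at the limit of > 100000 nM in this assay, at which 2 of the 3 values shown sit. Compound 1 stands at the limit of > 50000 nM in this assay, at which 1 of the 3 values shown sits. Within the data shown here, because all three values are limits, none of the measured steps can be read: a step that the two limits leave unreadable from compound 1 to compound 2, a step that the two limits leave unreadable from compound 1 to compound 3 and a step that the two limits leave unreadable from compound 2 to compound 3 are each hidden by the limits, and their sizes stay unknown. What the three compounds do show is that none of them reached a measurable half-maximal cytotoxic concentration in the tested range.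

Compound 4, `COc1ccc(S(=O)(=O)N(CC(N)=O)c2ccc(N(CC(N)=O)S(=O)(=O)c3ccc(NC(=O)CCN4CCN(C(C)C)CC4)cc3)c3ccccc23)cc1`, differs from compound 3 in one place: 4-isopropylpiperazin-1-yl in place of piperidin-1-yl on a saturated chain carbon, two bonds along the chain from a carbonyl carbon. Among the measured compounds shown here, the only comparable changes in this set, the steps from compound 1 onward at the same position on the chain, all ended at a limit, so they give no direction and no size for this new step. In this assay compound 4 is therefore expected to stay at or near the same limit, with no step beyond the scatter readable. The expected step is a number no higher from compound 3 to compound 4 (the limit leaves the size open), meaning essentially none. Compound 4 is estimated at 100000 nM, with a range from 30000 nM to 300000 nM.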

Compound 4, half-maximal cytotoxic concentration: > 100000 nM
Compound 4 was reported as a limit; the forecaster's own chance of this, stated with the estimate: 80%; the middle value lies on the limit itself.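

In this assay compound 4 gives > 100000 nM, which is again a limit of the assay and not a number. Among these compounds, no step from compound 1, compound 2 or compound 3 to compound 4 can therefore be read. The compounds shown leave open at what concentration any of them would reach half-maximal cytotoxicity, and whether the groups on the chain make any difference to it.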